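The compounds below may be only part of what the source reports. "The series", "measured", "known", "first", "only" and "open" are said of these compounds alone.

Of the compounds shown here, three that share one core have been measured so far in a functional assay on PC-3 cells (Homo sapiens) for cytotoxicity, read by MTT assay, with a stated time of 48 h (on this read-out lower numbers stand for stronger inhibition and higher numbers for weaker inhibition), and differ in their aromatic part. Compound 1 (`O=C1C=CC[C@H](c2cnc3ccccc3c2)O1`) gives 2500 nM there, compound 2 (`O=C1C=CC[C@H](c2cccc3ccccc23)O1`) gives 800 nM and compound 3 (`O=C1C=CC[C@H](c2ccnc3ccccc23)O1`) gives 9800 nM on the same read-out. Compound 2 therefore has the lowest number of the three, and both of the others lie beyond the usual scatter from it.

Compound 4 (`Cc1ccc2ccccc2c1[C@H]1CC=CC(=O)O1`) is compound 2 with one change (methyl in place of hydrogen on an aromatic carbon), a methyl in place of hydrogen on an aromatic carbon. Within the data shown here, none of the measured compounds carries a methyl, so the data offer no direct guide to this change. With compound 2 at 800 nM as the lowest of the three, a move upward seems the likelier expectation. In this assay a small rise that stays within the scatter is expected, estimated as a 1.6-fold higher number from compound 2 to compound 4 (0.21 log units; within the scatter) for this single added group. For compound 4 the estimated value is 1300 nM with 450 nM and 3800 nM as the expected lower and upper ends of the range.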

Compound 4, half-maximal inhibitory concentration: 130 nM
For compound 4 the middle estimate is 10-fold (1.00 log units) above the measured one; the whole stated range lies above it.
By their numbers in this assay, from the lowest: compound 4; then compound 2; then compound 1; then compound 3.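

In this assay, adding a methyl to the aromatic carbon ortho to a group of 7 heavy atoms gives a 6.2-fold lower number from compound 2 to compound 4 (0.79 log units; beyond the scatter), a change beyond the usual scatter. Among these compounds, the earlier compounds differed in their aromatic parts as a whole and offered no single-place step, so this is the first sign that one position on this ring of carbon only can take an added group and that a single added carbon can shift the read-out clearly. Nothing available explains why this methyl lowers the number.

From the compounds shown here alone, it remains open whether the drop is specific to methyl or would also appear with an ethyl, a methoxy group, a chlorine atom or an amine on the same carbon. It is also unclear whether a methyl on another carbon of this ring would have a similar effect.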